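This account rests on a few compounds, and the source may have more. Where it says the series, first, only, none or still open, it means among the compounds named here.

Measured in a functional assay on MGC-803 cells (Homo sapiens) for inhibition, read by CCK-8 assay, with a stated time of 48 h (on this read-out higher numbers stand for weaker inhibition and lower numbers for stronger inhibition), the values are:
Compound 1 `CCN1CCN(C(=S)SCC(=O)N(Cc2ccc(OC)cc2)c2cc(OC)c(OC)c(OC)c2)CC1` gives 9890 nM
Compound 2 `COc1ccc(CN(C(=O)CSC(=S)N2CCc3cc(OC)ccc32)c2cc(OC)c(OC)c(OC)c2)cc1` gives 11700 nM
Compound 3 `COc1ccc(CN(C(=O)CSC(=S)N2CCN(C(=O)OC(C)(C)C)CC2)c2ccc(Br)cc2)cc1` gives > 20000 nM (a limit)

For compound 3 the reading > 20000 nM is a limit and not a number. Compound 4 `COc1ccc(CN(C(=O)CSC(=S)N2CCN(C(=O)OC(C)(C)C)CC2)c2ccc(C)cc2)cc1` carries methyl in place of bromo on an aromatic carbon. Among the measured compounds shown here, the only measured step (a 1.2-fold higher number from compound 1 to compound 2 (0.07 log units; within the scatter)) swaps a group on a thiocarbonyl carbon, not this one, and lies within the scatter. It bears only loosely on this change, so no step beyond the scatter is expected in this assay in either direction. The estimated step reads (a number no higher from compound 3 to compound 4 (the limit leaves the size open)). For compound 4 the estimate is 20000 nM with an expected range of 9000 nM to 40000 nM and a fair chance of another limit reading.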

Compound 4, half-maximal inhibitory concentration: > 20000 nM
Compound 4 gave a limit, no number; the forecaster's own chance of this, stated with the estimate: 60%; the middle value lies on the limit itself.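

Compound 3 and compound 4 both give only a limit, so no step between them can be read: the limit of > 20000 nM in this assay, at which 2 of the 4 values shown sit.

The compounds shown leave open whether methyl in place of bromo on an aromatic carbon changes inhibition at all, and by how much.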